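Chloro for methoxy on the anilide of compound 2

The source may report more compounds than this note shows. Statements on the series, on what has been measured and on what is new or still open speak of the compounds shown alone.

Of the compounds shown here, two have so far been measured in an assay on HEK293 cells for activation of potassium channel subfamily T member 1 (Homo sapiens), read by thallium flux; a higher number here means that more compound is needed for the effect, a lower number that less compound is needed. Compound 1, `COc1ccc(Cl)cc1NC(=O)N1CC2(CCN(S(=O)(=O)N3CCC(C)CC3)CC2)C1`, returns only a limit of the assay, > 10000 nM. Compound 2, `COc1ccc(NC(=O)CN2CCN(S(=O)(=O)N3CCC(C)CC3)CC2)cc1`, likewise returns only a limit, > 10000 nM. Where compound 2 stands is therefore not a number but the ceiling of what this assay reports, and the same holds for the other value shown, as the limit of > 10000 nM in this assay, at which 2 of the 2 values shown sit, records.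

Compound 3, `CC1CCN(S(=O)(=O)N2CCN(CC(=O)Nc3ccc(Cl)cc3)CC2)CC1`, differs from compound 2 in one place: chloro in place of methoxy on an aromatic carbon. Among the measured compounds shown here, no step between two measured compounds is available to size this change, and the only anchors are the two limits.

On that footing no step beyond the scatter is expected in this assay; the expected step from compound 2 to compound 3 is a step that the limit leaves unreadable from compound 2 to compound 3, with the understanding that a limit on one side makes the step itself uncertain. For compound 3 the estimate in this assay is 15000 nM, between 3000 nM and 60000 nM, with a strong chance that the assay again reports only a limit rather than a number.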

Compound 3, half-maximal effective concentration: > 10000 nM
Compound 3 was reported as a limit; the forecaster's own chance of this, stated with the estimate: 80%; the middle value is on the limit's open side.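

Compound 2 and compound 3 both return only a limit in this assay, so putting chloro in place of methoxy gives no step that can be read: the limit of > 10000 nM in this assay, at which 3 of the 3 values shown sit.

The compounds shown leave open whether 4-chlorophenyl and 4-methoxyphenyl differ at all in this assay, since none of them gives a measured number there.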